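Methoxy added to a compound sitting at the limit

This account rests on a few compounds, and the source may have more. Where it says the series, first, only, none or still open, it means among the compounds named here.

Measured in an ADME assay on HEK293 cells (Homo sapiens) for cytotoxicity, with a stated time of 72 h; a higher number here means that more compound is needed for the effect, a lower number that less compound is needed:
Compound 1 `O=C(Nc1ccc(F)c(-c2nc3ccccc3s2)c1)c1cc([N+](=O)[O-])ccc1Cl`: > 25000 nM, a limit
Compound 2 `O=C(Nc1ccc(O)c(-c2nc3ccccc3s2)c1)c1cc([N+](=O)[O-])ccc1Cl`: > 25000 nM, a limit
Compound 3 `O=C(Nc1cccc(-c2nc3ccccc3s2)c1)c1cc([N+](=O)[O-])ccc1Cl`: > 27000 nM, a limit

Compound 3 has no number, only its limit of > 27000 nM. The other two compounds also stand at a limit: the limit of > 25000 nM in this assay, at which 2 of the 3 values shown sit.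

Compound 4 `COc1ccc(NC(=O)c2cc([N+](=O)[O-])ccc2Cl)cc1-c1nc2ccccc2s1` has not yet been measured. It carries methoxy in place of hydrogen on an aromatic carbon, ortho to a 1,3-benzothiazol-2-yl group and para to a large group: methoxy in place of hydrogen on an aromatic carbon.

The measured steps that bear on this change are a step that the two limits leave unreadable from compound 1 to compound 3 and a step that the two limits leave unreadable from compound 2 to compound 3, and a step that the two limits leave unreadable from compound 1 to compound 2 gives no size either. Compound 2, with hydroxy on that carbon, rests at the limit > 25000 nM, so no step beyond the scatter is expected in this assay, in either direction. The estimate means a number no higher from compound 3 to compound 4 (the limit leaves the size open), which is expected to stay within the scatter. For compound 4 the estimated value is 27000 nM, with an expected range from 13000 nM to 55000 nM.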

Compound 4, half-maximal effective concentration: > 25000 nM
Compound 4 ended at the assay's limit (the forecaster's own chance of this, stated with the estimate: 80%); the middle value is on the limit's open side.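

In this assay, compound 4 gives > 25000 nM, which is a limit. Among these compounds, compound 1, compound 2 and compound 3 also stand at limits, and no step to compound 4 can be read from any of them. The compounds shown leave open whether methoxy, hydrogen, hydroxy and fluoro differ at all on that carbon.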